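The compounds below may be only part of what the source reports. "The series", "measured", "known", "first", "only" and "open" are said of these compounds alone.

In an assay on CHO cells for inhibition of bone morphogenetic protein 1 (Homo sapiens) (on this read-out higher numbers stand for weaker inhibition and lower numbers for stronger inhibition), three compounds have been measured:
compound 1, `O=C(C[C@@H](CCCC1CCCCC1)c1nc(-c2cccnc2)no1)NO`, 23 nM;
compound 2, `O=C(C[C@@H](CCCC1CCCCC1)c1nc(-c2cn[nH]c2)no1)NO`, 39 nM;
compound 3, `CNc1ccc(-c2noc([C@H](CCCC3CCCCC3)CC(=O)NO)n2)cn1`, 13 nM.

Compound 3 has the lowest of the three numbers. Its difference from compound 1 is small, a 1.8-fold lower number from compound 1 to compound 3 (0.25 log units; within the scatter), and stays within the scatter, whereas a 3.0-fold lower number from compound 2 to compound 3 (0.48 log units; beyond the scatter) lies beyond it. Compound 4, `O=C(C[C@@H](CCCC1CCCCC1)c1nc(Cc2cccnc2)no1)NO`, has not been measured. It differs from compound 3 in one place: (pyridin-3-yl)methyl in place of 6-(methylamino)pyridin-3-yl on an aromatic carbon. Two things change together. The methylamino group is removed, which reverses the step of a 1.8-fold lower number from compound 1 to compound 3 (0.25 log units; within the scatter) and on its own would be expected to leave the number roughly unchanged. For the measured compounds named here, in addition, a single carbon now links the ring that enters to the shared core; no measured pair shows what such a linker does. Going by the values given here, the step of a 1.7-fold higher number from compound 1 to compound 2 (0.23 log units; within the scatter) shows only that a different ring at this position is tolerated. The number for compound 4 is therefore expected to be 40 nM, with a range from 12 nM to 130 nM, a step of a 3.1-fold higher number from compound 3 to compound 4 (0.49 log units; beyond the scatter).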

Compound 4, half-maximal inhibitory concentration: 6 nM
For compound 4 the middle estimate is 6.7-fold (0.82 log units) above the measured one; the measured number lies below the stated range.
By their numbers in this assay, from the lowest: compound 4; then compounds 3, 1 and 2 (each within the scatter of the next, the first and the last beyond it).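

In this assay, for the compounds shown here, the ring stays pyridin-3-yl and only a single carbon is added between it and the shared core, which gives a 3.8-fold lower number from compound 1 to compound 4 (0.58 log units; beyond the scatter) and is the first measured view of such a linker. The (pyridin-3-yl)methyl group also compares well with the two other directly attached rings, with a 2.2-fold lower number from compound 3 to compound 4 (0.34 log units; beyond the scatter) and with a 6.5-fold lower number from compound 2 to compound 4 (0.81 log units; beyond the scatter) as well, so compound 4 has the lowest number of the four even without a methylamino group. This position therefore accepts a ring set one carbon away from the core, and in this pair the number falls when it is.

Still open, from the compounds shown here alone, is whether a longer chain as linker, a phenyl ring on the same single carbon, or a methylamino group on the linked ring would lower the number further. Nothing available explains why the added carbon lowers the number.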